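Side chain step from compound 2 to compound 4

The compounds below may be only part of what the source reports. "The series", "measured", "known", "first", "only" and "open" are said of these compounds alone.

Measured so far:
- compound 1 `C/C=C/COc1cc(/C=C\c2cc(OC)c(OC)c(OC)c2)ccc1OC`: 135000 nM
- compound 2 `COc1ccc(COc2cc(/C=C\c3cc(OC)c(OC)c(OC)c3)ccc2OC)cc1`: 64000 nM
- compound 3 `COc1ccc(/C=C\c2cc(OC)c(OC)c(OC)c2)cc1OCc1ccc(Br)cc1`: 45000 nM

In an ADME assay on HEK293 cells (Homo sapiens) for inhibition, read by MTT assay, with a stated time of 3 days (on this read-out higher numbers stand for weaker inhibition and lower numbers for stronger inhibition), the highest number belongs to compound 1. Two modest steps lead down from it: a 2.1-fold lower number from compound 1 to compound 2 (0.32 log units; beyond the scatter) and a 3.0-fold lower number from compound 1 to compound 3 (0.48 log units; beyond the scatter). Compound 2 stands in the lower pair, and that pair is not separated: a 1.4-fold lower number from compound 2 to compound 3 (0.15 log units; within the scatter).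

Next comes compound 4 `COc1ccc(/C=C/CCCOc2cc(/C=C\c3cc(OC)c(OC)c(OC)c3)ccc2OC)cc1`. The change is 4-(4-methoxyphenyl)but-3-en-1-yl in place of 4-methoxyphenyl on a saturated chain carbon bound to an oxygen on an aromatic ring. Going by the values given here, no measured step tests this exchange directly. The closest evidence is the two modest steps at the same place, and compound 4 keeps the 4-methoxyphenyl group that compound 2 already carries. With so little to go on, the reading starts from compound 2 at 64000 nM, and only a small change is expected. In this assay the estimated change is a 1.2-fold lower number from compound 2 to compound 4 (0.09 log units; within the scatter), so no step beyond the scatter is expected, though the uncertainty is wide. For compound 4 the estimate is 52000 nM, with an expected range of 20000 nM to 130000 nM.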

Compound 4, half-maximal inhibitory concentration: 88000 nM
Compound 4: the middle estimate sits 1.7-fold (0.23 log units) below what was measured, and the stated range covers the measured number.
By their numbers in this assay, from the lowest: compounds 3, 2, 4 and 1 (each within the scatter of the next, the first and the last beyond it).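

On a saturated chain carbon bound to an oxygen on an aromatic ring, replacing 4-methoxyphenyl with 4-(4-methoxyphenyl)but-3-en-1-yl gives no separation in this assay: a 1.4-fold higher number from compound 2 to compound 4 (0.14 log units; within the scatter). Compound 4 also stays unseparated from both earlier neighbours, with a 2.0-fold higher number from compound 3 to compound 4 (0.29 log units; within the scatter) and a 1.5-fold lower number from compound 1 to compound 4 (0.19 log units; within the scatter), so the earlier split of compound 1 from compound 2 and compound 3 does not carry over to this longer group, even though it retains the 4-methoxyphenyl ring. No measured evidence is available to explain this result.

The compounds shown do not separate the added chain length from the double bond in 4-(4-methoxyphenyl)but-3-en-1-yl, so a saturated 4-(4-methoxyphenyl)butyl group would be the direct comparison with compound 4. Going by these compounds, it also remains open whether an amine or a carboxylic acid at this place, in place of the 4-methoxyphenyl ring, would move the number in this assay beyond the scatter from compound 2.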